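Lengthening a Sulfonamide Chain: Outlook for Cytotoxicity

The source may hold more compounds than are shown below. What is called first, only, known or untested is meant among the compounds shown, and "the series" means these compounds.

Compounds measured in an ADME assay on RAW264.7 cells (Mus musculus) for cytotoxicity, read by MTT assay, with a stated time of 48 h; a lower number here means a stronger inhibitor, a higher number a weaker inhibitor:
compound 1, `Cc1cc(NC(=O)c2cc(C(F)(F)F)cc(C(F)(F)F)c2)ccc1NS(C)(=O)=O`: > 250000 nM, a limit of the assay rather than a number
compound 2, `CCS(=O)(=O)Nc1ccc(NC(=O)c2cc(C(F)(F)F)cc(C(F)(F)F)c2)cc1C`: 124000 nM
compound 3, `CS(=O)(=O)Nc1ccc(NC(=O)c2cccc(C(F)(F)F)c2)cc1Cl`: > 250000 nM, again a limit of the assay rather than a number

Compound 1 reports only a limit in this assay. Compound 2, which differs from it by methyl in place of hydrogen on a saturated chain carbon bound to a sulfonyl sulfur, gives a number, and the step between them is an at least 2.0-fold lower number from compound 1 to compound 2 (0.30 log units; that floor lies within the scatter). Its true size is not pinned down, because the limit of > 250000 nM in this assay, at which 2 of the 3 values shown sit, is where the starting value sits. How the core of compound 3 differs from the core of compound 1 is not broken down here. Compound 3 itself also reports only a limit in this assay.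

Compound 4, `CCS(=O)(=O)Nc1ccc(NC(=O)c2cccc(C(F)(F)F)c2)cc1Cl`, has not yet been measured. It differs from compound 3 by methyl in place of hydrogen on a saturated chain carbon bound to a sulfonyl sulfur. The place of the change is described in the same words for both pairs, so this is the same change. Resting on the earlier step of an at least 2.0-fold lower number from compound 1 to compound 2 (0.30 log units; that floor lies within the scatter), the expected step here is an at least 1.6-fold lower number from compound 3 to compound 4 (0.22 log units; that floor lies within the scatter). That expectation is weak, since the earlier step starts from a limit and the new step does too. For compound 4 the estimated value in this assay is 150000 nM. The range for compound 4 is expected to run from 60000 nM to 300000 nM.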

Compound 4, half-maximal inhibitory concentration: 62400 nM
Estimate against measurement, compound 4: 2.4-fold (0.38 log units) above; low and high end bracket the measured number.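

In this assay, the change from methylsulfonyl to ethylsulfonyl on the core of compound 3 gives an at least 4.0-fold lower number from compound 3 to compound 4 (0.60 log units; beyond the scatter), so the lower number seen on the core of compound 1 has a counterpart here, and this time the step clears the usual scatter. Set side by side, the two steps can be compared only loosely: the same change on two cores in this assay, an at least 2.0-fold lower number (0.30 log units; that floor lies within the scatter) from compound 1 to compound 2 and an at least 4.0-fold lower number (0.60 log units; beyond the scatter) from compound 3 to compound 4; the limit leaves it open whether they differ. Each step starts from a limit of the assay rather than a number, so the pair shows the direction of the change on two cores, but neither its true size on either core nor whether that size carries over unchanged: the limit of > 250000 nM in this assay, at which 2 of the 4 values shown sit.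

The compounds shown go no further than ethylsulfonyl, so the effect in this assay of a longer chain such as propylsulfonyl, or of a cyclopropyl ring on the sulfonyl sulfur, remains open. Also open, from the compounds shown here alone, is how the same change of methyl for hydrogen would read on a core whose starting compound gives a true number rather than a limit, since only such a pair would fix the size of the step at both ends.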